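Chemokine receptor antagonist series: amide replaced by amidine

A few compounds are considered here, and "the series" means these few. Any claim that something is new, unique, unknown or untested is made for them only; others in the source may bear on it.

Measured so far:
- compound 1 `CNC(=O)c1cnc(N2CCN(C3CCN(Cc4ccc(Cl)cc4F)CC3)[C@@H](C)C2)c(Cl)c1`: 18 nM
- compound 2 `C[C@H]1CN(c2ncc(C(=O)NCc3ccc(F)c(F)c3)cc2Cl)CCN1C1CCN(Cc2ccc(Cl)cc2)CC1`: 6 nM
- compound 3 `CNC(=O)c1cnc(N2CCN(C3CCN(Cc4ccc(Cl)cc4)C(=O)C3)[C@@H](C)C2)c(Cl)c1`: 7000 nM

In a functional assay for antagonist activity at C-X-C chemokine receptor type 3 (Homo sapiens) (a lower number here means a stronger inhibitor, a higher number a weaker inhibitor), compound 2 gives 6 nM and stands lowest of the three numbers. Compound 1 sits nearest, beyond the scatter; compound 3, with its ring carbonyl, lies far beyond the scatter from both. Among the compounds with values here, no pair of these differs in only one place, so no single step is resolved; compound 1 shows that a small methylcarbamoyl on the shared core is compatible with a low number.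

Compound 4 `CCNC(=N)c1cnc(N2CCN(C3CCN(Cc4ccc(Cl)cc4)CC3)[C@@H](C)C2)c(Cl)c1` has not yet been measured in this assay. It differs from compound 2 in one place: a group of 5 heavy atoms (3 carbon, 2 nitrogen; no ring) in place of a group of 12 heavy atoms (8 carbon, 1 nitrogen, 1 oxygen, 2 fluorine; one six-membered aromatic ring of carbon only), on an aromatic carbon. The change removes the aromatic ring and the carbonyl of that side group and puts a short ethyl-bearing group in their place, closer in size to what compound 1 carries at the same position.

For compound 4 the step of a 17-fold higher number from compound 2 to compound 4 (1.22 log units; beyond the scatter) is expected to lie beyond the scatter, towards a higher number, given compound 2 at 6 nM and compound 1 at 18 nM with its small side group. Compound 4 is estimated at 100 nM, within a range of 20 nM to 800 nM.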

Compound 4, half-maximal inhibitory concentration: 83 nM
Beside the measured number, compound 4's estimate is 1.2-fold (0.08 log units) above it, within the range that was stated.
By their numbers in this assay, from the lowest: compound 2; then compound 1; then compound 4; then compound 3.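

In this assay, within the data shown here, putting the short ethyl-bearing group of 5 heavy atoms in place of the (3,4-difluorobenzyl)carbamoyl group gives a 14-fold higher number from compound 2 to compound 4 (1.14 log units; beyond the scatter), the only step in this set resolved at a single place, so this aromatic carbon, two atoms from the ring nitrogen, clearly responds to the choice of side group. The response is graded rather than all-or-nothing: without the aromatic ring and the carbonyl of that side group, compound 4 still gives 83 nM. No measurement here bears on the cause of the step.

The swap changes the aromatic ring, the carbonyl and the chain together, so the step cannot be divided among them. An ethylcarbamoyl group at this carbon, or a 3,4-difluorobenzyl group on the amidine nitrogen, would separate these contributions.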